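This account rests on a few compounds, and the source may have more. Where it says the series, first, only, none or still open, it means among the compounds named here.

Working notes on the series. The shared core carries a single varied substituent on a saturated ring carbon; compound 3 `CSC1CN(c2ccccc2)NC1=O` is the methylsulfanyl member. For the measured compounds named here, in an assay on isolated protein for inhibition of Polyunsaturated fatty acid 5-lipoxygenase (Rattus norvegicus) (on this read-out higher numbers stand for weaker inhibition and lower numbers for stronger inhibition), compound 3 gives 320 nM, the only plain number in this set. Compound 1 `COCCC1CN(c2ccccc2)NC1=O` gives 480 nM; 10300 nM; 350 nM (3 entries) in this assay, three entries that scatter widely (the several entries of compound 1 in this assay, 480 nM; 10300 nM; 350 nM (3 entries)). Compound 2 `CN(C)CCC1CN(c2ccccc2)NC1=O` gives in this assay only a limit, > 1000 nM. Going by the values given here, the single measured step is an at least 3.1-fold lower number from compound 2 to compound 3 (0.49 log units; beyond the scatter), and it is known only as a bound (the limit of > 1000 nM in this assay, at which 1 of the 3 values shown sits).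

Compound 4 `O=C1NN(c2ccccc2)CC1SCc1ccccc1` is not yet measured. From compound 3 to compound 4 the change is phenyl in place of hydrogen on a saturated chain carbon bound to a sulfur. Among the compounds with values here, no measured step touches this position: the step from compound 2 to compound 3 exchanges the whole substituent on the ring carbon and gives no direct guide for growing the chain on the sulfur. With no guide, the expected step is a 1.3-fold lower number from compound 3 to compound 4 (0.11 log units; within the scatter), a change not clearly beyond the scatter in either direction. Compound 4 is therefore estimated at 250 nM, with a range from 60 nM to 1000 nM.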

Compound 4, half-maximal inhibitory concentration: 180 nM
The estimate for compound 4 lay 1.4-fold (0.14 log units) above the measured number; measured number inside the range.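

In this assay, for the compounds shown here, the first measured change at this position, phenyl in place of hydrogen on a saturated chain carbon bound to a sulfur, gives a 1.8-fold lower number from compound 3 to compound 4 (0.25 log units; within the scatter). The methylsulfanyl chain of compound 3 can therefore carry a phenyl without a shift beyond the scatter, which the whole-substituent exchange from compound 2 to compound 3 could not show. The data shown give no measured cause for this step.

With a single step at this position, no trend with the size of the group on the sulfur can be drawn. As far as these compounds go, how a longer chain ending in phenyl, or a carboxylic acid or an amine in place of the phenyl, would read in this assay remains open.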